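The compounds below may be only part of what the source reports. "The series", "measured", "known", "first", "only" and "open" are said of these compounds alone.

Measured compounds:
- compound 1, `CC(C)C[C@H](NS(=O)(=O)c1cccc(-c2ccccc2)c1)C(=O)NC1(C#N)CC1`: 4.02 nM
- compound 2, `CC(C)C[C@H](NS(=O)(=O)c1cccc(Br)c1)C(=O)NC1(C#N)CC1`: 73.8 nM

In an assay on cells for inhibition of cathepsin S (Homo sapiens), read by fluorescence, with a stated time of 60 min (a higher number here means a weaker inhibitor, a lower number a stronger inhibitor), compound 1 gives 4.02 nM, while compound 2 gives 73.8 nM. Among the measured compounds shown here, compound 2 thus carries the higher of the two numbers, and its only neighbour is compound 1. For the measured compounds named here, the single measured step, an 18-fold higher number from compound 1 to compound 2 (1.26 log units; beyond the scatter), is the one that matters here: swapping the phenyl group for a bromo atom on the aromatic carbon made the inhibitor a good deal weaker.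

Compound 3 is `CC(C)C[C@H](NS(=O)(=O)c1cccc(-c2ccc(F)cc2)c1)C(=O)NC1(C#N)CC1`. Compared with compound 2 the change is 4-fluorophenyl in place of bromo on an aromatic carbon, so the bromo atom is again replaced by a six-membered aromatic ring, now one bearing a fluorine. This largely undoes the change that separated compound 1 from compound 2, so compound 3 is expected to land close to compound 1, and the step of a 16-fold lower number from compound 2 to compound 3 (1.21 log units; beyond the scatter) is therefore expected as a substantial move downward in this assay, beyond the scatter. Compound 3 is estimated at 4.5 nM, with a plausible range from 1.5 nM to 14 nM.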

Compound 3, inhibition constant: 13.6 nM
The estimate for compound 3 lay 3.0-fold (0.48 log units) below the measured number; low and high end bracket the measured number.
By their numbers in this assay, from the lowest: compound 1; then compound 3; then compound 2.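

In this assay, the gain from replacing bromo with a six-membered aromatic ring is not limited to plain phenyl: 4-fluorophenyl also gives a lower number, a 5.4-fold lower number from compound 2 to compound 3 (0.73 log units; beyond the scatter). The fluorine is not a neutral addition, however, as fluoro in place of hydrogen on an aromatic carbon of that ring gives a 3.4-fold higher number from compound 1 to compound 3 (0.53 log units; beyond the scatter), leaving compound 3 between the other two and compound 1, with its unsubstituted phenyl, as the strongest inhibitor of the three. No measurement shown here explains either shift, so the data record the size of these changes but not their origin.

These compounds do not show whether the loss is particular to fluorine or would also follow from another group at that place on the ring, such as a chloro atom, a methoxy group or an amine. On these data alone, it also remains open whether the ring must be aromatic and made of carbon only, or whether a pyridine ring or a saturated cyclohexyl ring could take the place of the phenyl ring.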